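Swapping the Selenium Group for Methylsulfanyl in Weak Cytotoxic Amides

This account rests on a few compounds, and the source may have more. Where it says the series, first, only, none or still open, it means among the compounds named here.

Compound 1, `O=C(/N=C(/NC(=O)c1cc(-c2ccccc2)nc2ccccc12)[Se]Cc1ccccc1)c1cc(-c2ccccc2)nc2ccccc12`: 39300 nM
Compound 2, `CS/C(=N\C(=O)c1cccs1)NC(=O)c1cccs1`: 39000 nM

In a functional assay on PC-3 cells (Homo sapiens) for cytotoxicity, read by MTT assay, with a stated time of 72 h (a higher number here means a weaker inhibitor of growth, a lower number a stronger inhibitor of growth), compound 1 gives 39300 nM, the highest of the two numbers in hand. Compound 2 gives 39000 nM in the same test; the two values sit within the scatter of each other, so neither compound can be called weaker or stronger than the other.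

Compound 3, `CS/C(=N\C(=O)c1cc(-c2ccccc2)nc2ccccc12)NC(=O)c1cc(-c2ccccc2)nc2ccccc12`, keeps the core of compound 1 and differs from it in one place: a group of 2 heavy atoms (1 carbon, 1 sulfur; no ring) in place of a group of 8 heavy atoms (7 carbon, 1 selenium; one six-membered aromatic ring of carbon only), on a carbon with a double bond to nitrogen. Compound 2 carries the same methylsulfanyl group on the same kind of carbon, though on a different core, and its number lands in the same range as compound 1. Among the compounds with values here, no step between two measured compounds is available to show how large such a change tends to be, so the expected step of a 1.0-fold higher number from compound 1 to compound 3 (0.01 log units; within the scatter) is none beyond the scatter. Compound 3 is therefore expected to give about 40000 nM, with a likely range from 15000 nM to 100000 nM.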

Compound 3, concentration for 50% growth inhibition: 7480 nM
Beside the measured number, compound 3's estimate is 5.3-fold (0.73 log units) above it, outside the stated range (below it).
By their numbers in this assay, from the lowest: compound 3; then compounds 2 and 1 (each within the scatter of the next).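

On the core of compound 1, the group on a carbon with a double bond to nitrogen matters for growth inhibition: in this assay, placing methylsulfanyl there instead of the selenium-bearing group of 8 heavy atoms gives a 5.3-fold lower number from compound 1 to compound 3 (0.72 log units; beyond the scatter), a modest step beyond the scatter. Within the data shown here, the earlier pair differed in more than one place, so this is the first measured step at this position, and it shows that the smaller sulfur group is the better of the two on this core. Nothing measured here bears on why the number falls.

The change replaces selenium with sulfur and removes a ring at once, so the compounds shown do not separate these two parts. Methylselanyl or benzylsulfanyl at this position would help tell them apart, and an ethylsulfanyl chain or an amine would show how far the trend extends.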